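The source may report more compounds than this note shows. Statements on the series, on what has been measured and on what is new or still open speak of the compounds shown alone.

Measured so far in a functional assay on A498 cells (Homo sapiens) for inhibition, read by sulforhodamine B assay, with a stated time of 48 h; on this read-out higher numbers stand for weaker inhibition of growth and lower numbers for stronger inhibition of growth:
compound 1 `COc1cc(-c2cc(/C=C/C(=O)c3ccc(N)cc3)[nH]n2)cc(OC)c1OC` gives 4330 nM
compound 2 `COc1cc(-c2cc(/C=C/C(=O)c3ccc(Cl)c(Cl)c3)[nH]n2)cc(OC)c1OC` gives 43000 nM

Compound 2 stands highest of the two numbers, the step being a 9.9-fold higher number from compound 1 to compound 2 (1.00 log units; beyond the scatter). Compound 3 `COc1ccc(C(=O)/C=C/c2cc(-c3cc(OC)c(OC)c(OC)c3)n[nH]2)cc1OC` differs from compound 2 by 3,4-dimethoxyphenyl in place of 3,4-dichlorophenyl on a carbonyl carbon. Among the compounds with values here, no measured step exchanges these two groups; the one step at this carbon, a 9.9-fold higher number from compound 1 to compound 2 (1.00 log units; beyond the scatter), shows only that the group on the carbonyl carbon can move the number well beyond the scatter. For compound 3 a step of a 2.9-fold lower number from compound 2 to compound 3 (0.46 log units; beyond the scatter) is expected, placing it between the two measured numbers with low confidence in direction. Compound 3 is estimated at 15000 nM (range 4000 nM to 60000 nM).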

Compound 3, concentration for total growth inhibition: 2980 nM
Compound 3: middle estimate off by 5.0-fold (0.70 log units), on the high side, and the stated range ends above it.
By their numbers in this assay, from the lowest: compounds 3 and 1 (each within the scatter of the next); then compound 2.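

In this assay, 3,4-dimethoxyphenyl in place of 3,4-dichlorophenyl on the carbonyl carbon gives a 14-fold lower number from compound 2 to compound 3 (1.16 log units; beyond the scatter) and so shows that the weak number of compound 2 is not common to all substituted phenyl groups at this position. The 3,4-dimethoxyphenyl and 4-aminophenyl groups are not separated here, with a 1.5-fold lower number from compound 1 to compound 3 (0.16 log units; within the scatter) as the step. Nothing at hand bears on the cause of these steps.

Going by these compounds, whether a plain phenyl group would sit with compound 2 or with compounds 1 and 3 remains open. So does the outcome for a carboxylic acid on that phenyl ring.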